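A few compounds are considered here, and "the series" means these few. Any claim that something is new, unique, unknown or untested is made for them only; others in the source may bear on it.

Measured so far:
- compound 1, `CC(/C=N/Nc1ccc([N+](=O)[O-])cc1)=N\NC(=O)c1ccccc1O`: 1640 nM
- compound 2, `CC(/C=N/Nc1ccc([N+](=O)[O-])cc1)=N\NC(=O)c1ccc(C(F)(F)F)cc1`: > 12000 nM

All numbers here come from a functional assay on cells (Splenocyte, Mus musculus, strain BALB/c) for inhibition, read by scintillation counting and thymidine incorporation, with a stated time of 72 h; a higher number here means a weaker inhibitor, a lower number a stronger inhibitor. Going by the values given here, compound 1 is the only compound of the pair with a number rather than a limit, giving 1640 nM in this assay. Compound 2 is reported in this assay only as > 12000 nM, which is a limit of the assay and not a number. Of the two values shown, one sits at the limit of > 12000 nM in this assay, at which 1 of the 2 values shown sits. No step between measured compounds is listed, so nothing has yet been computed on what a single change on the carbonyl carbon does.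

Compound 3, `CC(/C=N/Nc1ccc([N+](=O)[O-])cc1)=N\NC(=O)c1ccc(Cl)cc1`, is still to be measured. Against compound 1 the change is 4-chlorophenyl in place of 2-hydroxyphenyl on a carbonyl carbon. The second value shown in this series is a limit, so the step from compound 1 to compound 3 in this assay is expected to be a loss beyond the scatter rather than none. Compound 3 is expected to give 7000 nM in this assay, within 2500 nM to 20000 nM, a step of a 4.3-fold higher number from compound 1 to compound 3 (0.63 log units; beyond the scatter) that is an estimate, with a real chance that only a limit is reported.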

Compound 3, half-maximal inhibitory concentration: 4200 nM
The estimate for compound 3 lay 1.7-fold (0.22 log units) above the measured number; low and high end bracket the measured number.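

In this assay, going by these compounds alone, 4-chlorophenyl in place of 2-hydroxyphenyl on the carbonyl carbon gives a 2.6-fold higher number from compound 1 to compound 3 (0.41 log units; beyond the scatter): a real but modest loss, and the first measured value for a group at this position with 0 hydrogen-bond donors and 0 hydrogen-bond acceptors. Chloro in place of trifluoromethyl on the aromatic carbon gives an at least 2.8-fold lower number from compound 2 to compound 3 (0.45 log units; beyond the scatter), which shows that the read-out also responds to a change of the substituent alone, with the aromatic ring kept. The size of that second step stays open-ended because the value for compound 2 is a limit of the assay and not a number: the limit of > 12000 nM in this assay, at which 1 of the 3 values shown sits.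

The step from compound 1 changes both the substituent and its place on the ring, so the compounds shown do not separate the two; 4-hydroxyphenyl and 2-chlorophenyl would bear on that question. Going by these compounds, how an amine or a carboxylic acid on this ring, or a short alkyl chain in place of the ring on the carbonyl carbon, would read in this assay also remains open.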